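Shortening the alkenyl side chain in an aryl enone series

The source may hold more compounds than are shown below. What is called first, only, known or untested is meant among the compounds shown, and "the series" means these compounds.

compound 1 `C=C(CCCC)C(=O)c1ccc(OCC(=O)OC)c(C)c1C`: 8600 nM
compound 2 `C=C(CCCC)C(=O)c1ccc(OC(C)C(=O)OC)c(C)c1C`: 5200 nM

Both compounds were tested in a functional assay on HL-60 cells (Homo sapiens) for antiproliferative activity, with a stated time of 72 h; a higher number here means a weaker inhibitor of growth, a lower number a stronger inhibitor of growth. Among the compounds with values here, compound 2 stands at one end of the two numbers, and the only other number, that of compound 1, lies a 1.7-fold lower number from compound 1 to compound 2 (0.22 log units; within the scatter) away, a step within the scatter, so the two values cannot be told apart. That single step concerns a methyl in place of hydrogen on a saturated chain carbon bound to a carbonyl carbon and an oxygen on an aromatic ring.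

Compound 3 `C=C(CC)C(=O)c1ccc(OC(C)C(=O)OC)c(C)c1C` differs from compound 2 at another place: hydrogen in place of ethyl on a saturated chain carbon, two bonds along the chain from a double-bonded chain carbon. Within the data shown here, no measured step touches this part of the structure, so there is no precedent for either direction, and the one measured step cannot be carried over. With nothing to point one way or the other, compound 3 is expected to stay close to compound 2. The estimated step is a 1.3-fold higher number from compound 2 to compound 3 (0.13 log units; within the scatter), not expected to exceed the scatter. Compound 3 is therefore estimated at 7000 nM, with a range from 2500 nM to 20000 nM.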

Compound 3, concentration for 50% growth inhibition: 4600 nM
For compound 3 the middle estimate is 1.5-fold (0.18 log units) above the measured one, within the range that was stated.
By their numbers in this assay, from the lowest: compounds 3, 2 and 1 (each within the scatter of the next).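

Cutting the side chain from butyl to ethyl gives a 1.1-fold lower number from compound 2 to compound 3 (0.05 log units; within the scatter) in this assay and so leaves two values that cannot be told apart. Within the data shown here, this is the first reading from this part of the structure, since the earlier step concerned a different place, and it shows that two carbon atoms can go from the side chain without a step that stands out from the scatter, at least in this one pair of compounds. No measured evidence here bears on this result.

The compounds shown leave open how far the side chain can be altered before growth inhibition moves clearly, for example by cutting it further to a methyl group, lengthening it to hexyl, or ending it in an amine or a carboxylic acid. Among these compounds, they also leave open whether the same shortening would read the same way on compound 1, which lacks the methyl group of compound 2, as all three values so far lie within the scatter of the next.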